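Sulfonamide hydrazides on ovarian cells: notes toward compound 3

The source may report more compounds than this note shows. Statements on the series, on what has been measured and on what is new or still open speak of the compounds shown alone.

Measured so far in a functional assay on OVCAR-3 cells (Homo sapiens) for antiproliferative activity, read by MTT assay, with a stated time of 24 h; on this read-out higher numbers stand for weaker inhibition and lower numbers for stronger inhibition:
compound 1 `Cc1ccccc1NNC(=O)c1ccc(NS(=O)(=O)c2cnc(O)nc2O)cc1`: > 20000 nM
compound 2 `O=C(NNc1ccc(F)cc1)c1cccc(NS(=O)(=O)c2cnc(O)nc2O)c1`: > 20000 nM

The reading for compound 1 is a limit of the assay, not a number, and sits at the limit of > 20000 nM in this assay, at which 2 of the 2 values shown sit. The reading for compound 2 is likewise only a limit. Compound 3 `O=C(NNC(=O)c1ccccc1Cl)c1ccc(NS(=O)(=O)c2cnc(O)nc2O)cc1` is not yet measured. It differs from compound 1 in one place: (2-chlorophenyl)carbonyl in place of 2-methylphenyl on an amine nitrogen. Among the compounds with values here, no step between measured compounds is available, so the expectation rests on compound 1 alone. The step that the limit leaves unreadable from compound 1 to compound 3 is expected to be none beyond the scatter. Compound 3 is estimated at 25000 nM, with a range from 8000 nM to 80000 nM, and another limit reading is the most likely outcome.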

Compound 3, half-maximal inhibitory concentration: 5220 nM
For compound 3 the middle estimate is 4.8-fold (0.68 log units) above the measured one; the whole stated range lies above it.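

In this assay, within the data shown here, this position on the amine nitrogen proves able to move the read-out: (2-chlorophenyl)carbonyl in place of 2-methylphenyl gives an at least 3.8-fold lower number from compound 1 to compound 3 (0.58 log units; beyond the scatter) and yields the first reading that is a number. The full size of the step cannot be read because the value for compound 1 is only a limit of the assay: the limit of > 20000 nM in this assay, at which 2 of the 3 values shown sit.

The change brings in a carbonyl and a chlorine together, and the compounds shown do not separate the two. Going by these compounds, whether an acetyl group or a longer alkyl chain on this nitrogen would give a numerical reading remains open.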